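Aryl amide series: toward the 4-methylphenyl analogue

The compounds below may be only part of what the source reports. "The series", "measured", "known", "first", "only" and "open" are said of these compounds alone.

Compound 3 `N=c1oc2c(O)cccc2cc1C(=O)Nc1cccc(Cl)c1` sits at a limit in an assay on isolated protein for inhibition of aldo-keto reductase family 1 member C4 (Homo sapiens), using NADPH; on this read-out lower numbers stand for stronger inhibition and higher numbers for weaker inhibition: compound 3 gives > 10000 nM, a limit of the assay and not a number. Compound 1 `N=c1oc2c(O)cccc2cc1C(=O)Nc1cccc(F)c1` likewise gives > 10000 nM, again a limit. Compound 2 `N=c1oc2c(O)cccc2cc1C(=O)Nc1ccc(F)cc1` gives > 10000 nM, also a limit. The measured ground is thus (the limit of > 10000 nM in this assay, at which 3 of the 3 values shown sit), and the steps a step that the two limits leave unreadable from compound 1 to compound 2, a step that the two limits leave unreadable from compound 1 to compound 3 and a step that the two limits leave unreadable from compound 2 to compound 3 stay unreadable in size and direction. Compound 4 `Cc1ccc(NC(=O)c2cc3cccc(O)c3oc2=N)cc1` differs from compound 3 by 4-methylphenyl in place of 3-chlorophenyl on an amide-type nitrogen. Among the measured compounds shown here, no measured step gives this change a readable size, so the expected step that the limit leaves unreadable from compound 3 to compound 4 is taken as none beyond the scatter. Compound 4 is therefore estimated at 15000 nM, in the range 5000 nM to 50000 nM, most likely again reported only as a limit.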

Compound 4, half-maximal inhibitory concentration: > 10000 nM
Compound 4: only a limit was reported; the forecaster's own chance of this, stated with the estimate: 80%; the middle value is on the limit's open side.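

Compound 4 adds no readable step, and all steps among compound 1, compound 2, compound 3 and compound 4 stay unreadable in size and direction: the limit of > 10000 nM in this assay, at which 4 of the 4 values shown sit.

On these data alone, what true inhibition values these four compounds have in this assay stays open.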